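The source may hold more compounds than are shown below. What is called first, only, known or untested is meant among the compounds shown, and "the series" means these compounds.

Measured compounds and their values in an assay on CHO cells for displacement of a labelled ligand from adenosine receptor A3 (Homo sapiens), read by scintillation counting, with a stated time of 120 min, tested at 1 uM; a higher number here means more inhibition at the concentration tested (going by the name of the read-out), a lower number less inhibition:
compound 1 `Cc1nc2sc(-c3ccc(C(F)(F)F)cc3)nc2c(=O)[nH]1`: 32%
compound 2 `Cc1nc2sc(Nc3ccccc3)nc2c(=O)[nH]1`: 45%
compound 3 `COc1ccc(Nc2nc3c(=O)[nH]c(C)nc3s2)cc1`: 36%

Compound 3 stands second highest of these three numbers. Its nearest neighbour is compound 1, whose value lies a little lower, and the two fall within the scatter of each other. Compound 2 sits furthest away, though the step of a number 9 percentage points lower from compound 2 to compound 3 (within the scatter) is also within the scatter, so none of the three can be ranked against the others.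

Compound 4 `Cc1nc2sc(Nc3ccc(Cl)cc3)nc2c(=O)[nH]1` arises from compound 3 by the change (chloro in place of methoxy on an aromatic carbon). Among the measured compounds shown here, only one measured step touches the same ring: the step of a number 9 percentage points lower from compound 2 to compound 3 (within the scatter), where a methoxy replaced a hydrogen, and it stayed within the scatter. For the measured compounds named here, no measured step swaps a methoxy for a chloro, so the expectation rests on that single neighbouring step alone.

Compound 4 is therefore expected to stay close to compound 3, with the estimated step of a number 4 percentage points higher from compound 3 to compound 4 (within the scatter) not beyond the scatter. In this assay compound 4 is estimated at 40%, with a plausible range from 25% to 55%.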

Compound 4, a percentage reported as inhibition, at one concentration (the size of the read-out at that concentration, not a potency): 49%
The estimate for compound 4 lay 9 percentage points below the measured number; low and high end bracket the measured number.
By their numbers in this assay, from the lowest: compounds 1, 3, 2 and 4 (each within the scatter of the next, the first and the last beyond it).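

In this assay, among the compounds shown here, putting chloro in place of methoxy on the aromatic carbon para to a large group gives a number 13 percentage points higher from compound 3 to compound 4 (beyond the scatter) and is the first step to pass beyond the scatter, so the choice of group at this position can change the read-out, though only modestly. Measured against hydrogen, neither group stands apart: chloro gives a number 4 percentage points higher from compound 2 to compound 4 (within the scatter) and methoxy gives a number 9 percentage points lower from compound 2 to compound 3 (within the scatter) and both steps stay within the scatter, so the position shows up only when the two groups are compared directly, as opposite-direction steps from the same starting point add up to a difference that can be read. Nothing available explains why methoxy and chloro differ here.

Only hydrogen, methoxy and chloro are shown at this position, so it remains open whether a fluoro, a nitrile, a carboxylic acid or an amine would extend this difference or erase it. From the compounds shown here alone, each number is also a single reading at one concentration rather than a potency, so how far these compounds truly differ in potency remains unknown.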